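The compounds below may be only part of what the source reports. "The series", "measured", "known", "first", "only" and "open" are said of these compounds alone.

Compound 1, `O=C(COc1cccc2ccccc12)N/N=C/c1ccc(Cl)cc1`: 100 ug/mL. Compound 2, `C/C(=N\NC(=O)COc1cccc2ccccc12)c1ccc(O)cc1`: 20 ug/mL. Compound 3, `O=C(COc1cccc2ccccc12)N/N=C/c1ccccc1`: 100 ug/mL.

All three were measured in an ADME assay on HEL cells (Homo sapiens) for cytotoxicity; a higher number here means that more compound is tolerated, a lower number that less compound is tolerated. Compound 2 stands lowest of the three numbers; compound 1 and compound 3 sit at the same higher value, and both gaps from compound 2 lie beyond the scatter. Among the measured compounds shown here, the single measured step, no change at the digits printed from compound 1 to compound 3 (within the scatter), exchanges hydrogen for chloro on an aromatic carbon and stays flat. Compound 4, `C/C(=N\NC(=O)COc1cccc2ccccc12)c1ccc(Br)cc1`, differs from compound 2 as follows: bromo in place of hydroxy on an aromatic carbon. For the measured compounds named here, no measured step swaps hydroxy for a halogen, so the flat chloro step is only a loose guide. Compound 4 is therefore expected to give 50 ug/mL (range 20 ug/mL to 100 ug/mL), an estimated step of a 2.5-fold higher number from compound 2 to compound 4 (0.40 log units; beyond the scatter).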

Compound 4, minimum cytotoxic concentration: 20 ug/mL
Compound 4: the middle estimate sits 2.5-fold (0.40 log units) above what was measured, and the stated range covers the measured number.
By their numbers in this assay, from the lowest: compounds 2 and 4 (each within the scatter of the next); then compounds 1 and 3 (each within the scatter of the next).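

In this assay the exchange of hydroxy for bromo, on the aromatic carbon para to a large group, gives no change at the digits printed from compound 2 to compound 4 (within the scatter) and extends the flat reading from the chloro step to a second position and a different pair of groups. At this position, the number compound 2 gives therefore does not depend on keeping the hydroxy group. No measurement available here explains this result.

As far as these compounds go, whether an amine or a carboxylic acid at this position would leave the number unchanged remains open. So does the contribution of the methyl group shared by compound 2 and compound 4, which no pair differing in one place isolates.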